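The compounds below may be only part of what the source reports. "The series", "measured", "known", "first", "only" and "open" are said of these compounds alone.

Compound 2 `CC(=O)c1c(NNc2ccc(Br)cc2)cc(C)oc1=O` stands lowest of the two measured compounds in a functional assay on the whole organism for inhibition, with Rattus norvegicus as the target, read by paw edema, with a stated time of 3 h, at a dose of 50 mg/kg (a higher number here means more inhibition at the dose given (going by the name of the read-out), a lower number less inhibition), where compound 2 gives 40.4%. Among the compounds with values here, compound 1 `CC(=O)c1c(NNc2ccc(C)cc2)cc(C)oc1=O` gives 59.6% in this assay, and the only measured step, a number 19.2 percentage points lower from compound 1 to compound 2 (beyond the scatter), was modest. Compound 3 `CC(=O)c1c(NNc2ccc([N+](=O)[O-])cc2)cc(C)oc1=O` differs from compound 2 by nitro in place of bromo on an aromatic carbon. Within the data shown here, no measured step exchanges bromo for nitro, so the direction of this change cannot be read from the numbers; the one measured step only shows that a swap at this position shifted the read-out moderately. Compound 3 is therefore expected to land near compound 2, with an estimated step of a number 0.4 percentage points lower from compound 2 to compound 3 (within the scatter), not beyond the scatter. The estimate for compound 3 is 40%, expected between 25% and 55%.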

Compound 3, a percentage reported as inhibition, in the whole organism at one dose (the size of the read-out at that dose, not a potency): 45.5%
For compound 3 the middle estimate is 5.5 percentage points below the measured one, and the stated range covers the measured number.
By their numbers in this assay, from the lowest: compounds 2 and 3 (each within the scatter of the next); then compound 1.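

In this assay, nitro and bromo cannot be told apart at this position, with a number 5.1 percentage points higher from compound 2 to compound 3 (within the scatter). Nitro also stays apart from methyl, with a number 14.1 percentage points lower from compound 1 to compound 3 (beyond the scatter), so among these three compounds the methyl of compound 1 alone stands out, while a one-atom and a three-atom group read alike. No further data are available to explain this. From the compounds shown here alone, whether an amine or a carboxylic acid at this position would read like methyl or like bromo and nitro stays open. So does whether a longer chain, such as ethyl, would keep the reading of methyl.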